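The source may hold more compounds than are shown below. What is called first, only, known or untested is meant among the compounds shown, and "the series" means these compounds.

Compound 1 `CCCCCCCCc1ccc(OCC(=O)Cn2nnc(-c3ccc(Cl)cc3)n2)cc1` gives 35 nM in an assay on microsomes from brain for inhibition of Fatty-acid amide hydrolase 1 (Rattus norvegicus), read by fluorescence and HPLC, with a stated time of 60 min (a higher number here means a weaker inhibitor, a lower number a stronger inhibitor), the highest of the three numbers on hand. Compound 2 `CCCCCCCCc1ccc(OCC(=O)Cn2nnc(-c3cccc(C(=O)OC)c3)n2)cc1` gives 34 nM in this assay, and compound 3 `CCCCCCCCc1ccc(OCC(=O)Cn2nnc(-c3ccccn3)n2)cc1` gives 18 nM. The step of a 1.0-fold lower number from compound 1 to compound 2 (0.01 log units; within the scatter) and the step of a 1.9-fold lower number from compound 1 to compound 3 (0.29 log units; within the scatter) both stay within the scatter, as does the step of a 1.9-fold lower number from compound 2 to compound 3 (0.28 log units; within the scatter); exchanging the group at this position of the shared core has so far left the number essentially unchanged. Compound 4 `CCCCCCCCc1ccc(OCC(=O)Cn2nnc(-c3cccs3)n2)cc1` differs from compound 1 by thiophen-2-yl in place of 4-chlorophenyl on an aromatic carbon. The measured steps that bear on this exchange are those at the same position, a 1.0-fold lower number from compound 1 to compound 2 (0.01 log units; within the scatter) and a 1.9-fold lower number from compound 1 to compound 3 (0.29 log units; within the scatter), each of them small. Because both a 1.0-fold lower number from compound 1 to compound 2 (0.01 log units; within the scatter) and a 1.9-fold lower number from compound 1 to compound 3 (0.29 log units; within the scatter) fall inside the scatter, no step beyond the scatter is expected for compound 4 in this assay. Compound 4 is therefore expected to give 30 nM, with a range of 12 nM to 75 nM. This amounts to an expected step of a 1.2-fold lower number from compound 1 to compound 4 (0.07 log units; within the scatter).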

Compound 4, half-maximal inhibitory concentration: 32 nM
Compound 4: the middle estimate sits 1.1-fold (0.03 log units) below what was measured, within the range that was stated.
By their numbers in this assay, from the lowest: compounds 3, 4, 2 and 1 (each within the scatter of the next).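

In this assay the position also accepts a five-membered aromatic ring with 1 hetero atom: thiophen-2-yl, with 5 heavy atoms, in place of the six-membered 4-chlorophenyl, with 7, gives a 1.1-fold lower number from compound 1 to compound 4 (0.04 log units; within the scatter) and so no step beyond the scatter. The two other new steps, a 1.8-fold higher number from compound 3 to compound 4 (0.25 log units; within the scatter) and a 1.1-fold lower number from compound 2 to compound 4 (0.03 log units; within the scatter), also stay within the scatter, so ring size joins the exchanges that do not separate these compounds in this assay. No measurement at hand explains this result.

The compounds shown all carry an aromatic ring at this position, so it remains open whether a saturated ring such as piperidine would give a step beyond the scatter. From the compounds shown here alone, it also remains open whether a carboxylic acid or an amine on the aromatic ring would do so.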